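A Halogen Returns to the Aryl Group

The source may hold more compounds than are shown below. What is called first, only, known or untested is meant among the compounds shown, and "the series" means these compounds.

For the measured compounds named here, in an assay on NIH3T3 cells with Urotensin-2 receptor (Homo sapiens) as the target (a lower number here means that less compound is needed, a higher number that more compound is needed for the effect), compound 2 `Cc1ccc(C(=O)OC(CCN(C)C)c2ccc(Cl)cc2)cc1` gives 2750 nM, the higher of the two numbers measured so far; compound 1 `Cc1c(Cl)cccc1C(=O)OC(CCN(C)C)c1ccc(Cl)cc1` gives 1120 nM. Compound 3 `Cc1cc(Br)ccc1C(=O)OC(CCN(C)C)c1ccc(Cl)cc1` differs from compound 2 by 4-bromo-2-methylphenyl in place of 4-methylphenyl on a carbonyl carbon. Going by the values given here, the only measured step that bears on this change, a 2.5-fold higher number from compound 1 to compound 2 (0.39 log units; beyond the scatter), went from a phenyl carrying both a halogen and a methyl to a plain 4-methylphenyl. Compound 3 brings a halogen and a methyl back onto that phenyl, so a modest step downward, roughly reversing that one, is expected: a 2.3-fold lower number from compound 2 to compound 3 (0.36 log units; beyond the scatter). Compound 3 is therefore estimated at 1200 nM, between 500 nM and 3000 nM.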

Compound 3, half-maximal effective concentration: 1070 nM
Compound 3: middle estimate off by 1.1-fold (0.05 log units), on the high side, and the stated range covers the measured number.
By their numbers in this assay, from the lowest: compounds 3 and 1 (each within the scatter of the next); then compound 2.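

The 4-bromo-2-methylphenyl group on the carbonyl carbon gives a 2.6-fold lower number from compound 2 to compound 3 (0.41 log units; beyond the scatter) and is the second aryl group carrying both a halogen and a methyl to sit below compound 2. Set against the 3-chloro-2-methylphenyl group, it gives a 1.0-fold lower number from compound 1 to compound 3 (0.02 log units; within the scatter) and so cannot be told apart from that group, although the halogen and its place on the ring both differ. Nothing measured here explains these numbers. Going by these compounds, it remains open whether the bromine or the 2-methyl carries the step, and how a plain phenyl or a 4-methoxyphenyl would compare.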